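This account rests on a few compounds, and the source may have more. Where it says the series, first, only, none or still open, it means among the compounds named here.

Measured so far:
compound 1 `S=C(Nc1ccccc1)Nc1ccc2[nH]ccc2c1`, 81.4%
compound 2 `S=C(Nc1ccc(Br)cc1)Nc1ccc2[nH]ccc2c1`, 82%

In an ADME assay on isolated protein for inhibition of peroxidase (Raphanus sativus), read by fluorescence and Amplex Red, tested at 5 uM (a higher number here means a weaker effect of the compound at the concentration tested, a lower number a stronger effect), compound 1 gives 81.4% and compound 2 gives 82%; the two stand at the same level, within the scatter of each other. Within the data shown here, the single step, a number 0.6 percentage points higher from compound 1 to compound 2 (within the scatter), shows no effect of a substituent at that place.

Compound 3 `CCOC(=O)c1ccc(NC(=S)Nc2ccc3[nH]ccc3c2)cc1` differs from compound 2 by ethoxycarbonyl in place of bromo on an aromatic carbon. Among the measured compounds shown here, only the step from compound 1 to compound 2 bears on this, and it lay within the scatter; the ethoxycarbonyl group is untested, so no step beyond the scatter is expected in this assay, as a number 2 percentage points lower from compound 2 to compound 3 (within the scatter). Compound 3 is estimated at 80%, between 64% and 93%.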

Compound 3, a percentage reported as activity, at one concentration (the size of the read-out at that concentration, not a potency): 65.8%
Compound 3: the middle estimate sits 14.2 percentage points above what was measured; low and high end bracket the measured number.
By their numbers in this assay, from the lowest: compound 3; then compounds 1 and 2 (each within the scatter of the next).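

In this assay the position para to a large group turns out to respond to substitution: ethoxycarbonyl gives a stronger effect, with a number 16.2 percentage points lower from compound 2 to compound 3 (beyond the scatter) and a number 15.6 percentage points lower from compound 1 to compound 3 (beyond the scatter), whereas bromo and hydrogen stand within the scatter of each other. Unlike bromo, the entering group brings a carbonyl and hydrogen-bond acceptors, but the three compounds do not separate these features from its size. No measurement at hand gives a reason for this step.

From the compounds shown here alone, it remains open whether a carboxylic acid, a primary amide or a nitrile at this place would give a similar step. Also open, going by these compounds, is whether a longer ester chain would go further.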